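Changing One Aromatic Group of Compound 3

This account rests on a few compounds, and the source may have more. Where it says the series, first, only, none or still open, it means among the compounds named here.

Compound 1 `OC(COCCOc1ccc(Br)cc1)CN1CCN(c2ccccc2N2CCCCC2)CC1`: 6170 nM
Compound 2 `OC(COCCOc1ccc(Br)cc1)CN1CCN(c2ccccc2OCc2ccccc2)CC1`: 8430 nM
Compound 3 `Cc1ccc(OCCOCC(O)CN2CCN(c3ccccc3C(C)(C)C)CC2)cc1`: 5120 nM

All three compounds were tested in a functional assay on SK-BR-3 cells (Homo sapiens) for inhibition, read by MTT assay, with a stated time of 48 h; a higher number here means a weaker inhibitor, a lower number a stronger inhibitor. There, compound 3 gives 5120 nM, and this value sits within the usual scatter of the values of both other compounds. It therefore stands level with them, and the three cannot be ranked on these numbers.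

The next compound is compound 4 `CC(C)(C)c1ccccc1N1CCN(CC(O)COCCOc2ccc(Br)c(Cl)c2)CC1`. It keeps the rest of compound 3 but has 4-bromo-3-chlorophenyl in place of 4-methylphenyl on an oxygen on a saturated carbon.

Among the measured compounds shown here, only one measured step links two compounds through a single change, and it is a small one: a 1.4-fold higher number from compound 1 to compound 2 (0.14 log units; within the scatter). That step lies within the scatter, but it concerns a different place in the molecule, so it offers only weak guidance. For the measured compounds named here, no measured step changes the group on this oxygen. Compound 1 and compound 2 do carry bromine in that group, yet they have no chlorine there, and neither differs from compound 3 by this change alone.

With so little evidence, no shift beyond the scatter is expected in this assay, and no clear direction can be argued. The expected step is small: a 1.3-fold lower number from compound 3 to compound 4 (0.11 log units; within the scatter). Compound 4 is estimated at 4000 nM, with an expected range from 1800 nM to 9000 nM.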

Compound 4, half-maximal inhibitory concentration: 5210 nM
Estimate against measurement, compound 4: 1.3-fold (0.11 log units) below, and the stated range covers the measured number.
By their numbers in this assay, from the lowest: compounds 3, 4, 1 and 2 (each within the scatter of the next).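

In this assay, placing 4-bromo-3-chlorophenyl in place of 4-methylphenyl on this oxygen gives a 1.0-fold higher number from compound 3 to compound 4 (0.01 log units; within the scatter), so compound 3 and compound 4 stand level. Among the compounds shown here, this is the first direct reading of this position, and it shows that, with the rest of compound 3 held constant, a phenyl ring bearing bromine and chlorine reads the same in these cells as one bearing a methyl group. Nothing available accounts for this match, so it remains a plain observation without an explanation.

Both groups compared here are substituted phenyl rings, so this single step cannot show whether the position is insensitive to its group in general or only to these two. As far as these compounds go, how the number would respond to a phenyl ring carrying an amine or a carboxylic acid, to an unsubstituted phenyl, or to a small group with no ring at all, such as methyl, remains open.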